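Cyano for Hydrogen: From Compound 1 to Compound 3

The source may report more compounds than this note shows. Statements on the series, on what has been measured and on what is new or still open speak of the compounds shown alone.

Measured compounds:
compound 1 `COC(=O)c1ccc(NCc2cncn2Cc2ccccc2)cc1-c1ccccc1`: > 1000 nM
compound 2 `c1ccc(Cn2cncc2CNc2cccc(-c3ccccc3)c2)cc1`: > 750 nM

In a toxicity assay on NIH3T3 cells (Mus musculus) for cytotoxicity, read by resazurin assay (a lower number here means that less compound is needed, a higher number that more compound is needed for the effect), compound 1 returns only a limit, > 1000 nM. Compound 2 likewise returns only a limit in this assay, > 750 nM. The step that the two limits leave unreadable from compound 1 to compound 2 cannot be read from these two limits.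

Compound 3 `COC(=O)c1ccc(NCc2cncn2Cc2ccccc2C#N)cc1-c1ccccc1` differs from compound 1 by cyano in place of hydrogen on an aromatic carbon. Within the data shown here, no measured step bears on this change, and compound 1 itself stands only at a limit. Compound 3 is therefore expected to stay around that limit, a step that the limit leaves unreadable from compound 1 to compound 3, with an estimate of 2500 nM and a range from 800 nM to 10000 nM.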

Compound 3, half-maximal effective concentration: 25000 nM
Compound 3: middle estimate off by 10-fold (1.00 log units), on the low side, outside the stated range (above it).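

No step from compound 1 to compound 3 can be read, since compound 1 stands only at a limit: the limit of > 1000 nM in this assay, at which 1 of the 3 values shown sits.

The compounds shown leave open how large the change from benzyl to 2-cyanobenzyl is in this assay.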